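The source may hold more compounds than are shown below. What is called first, only, known or untested is meant among the compounds shown, and "the series" means these compounds.

Measured in a functional assay on HUVEC cells (Homo sapiens) for antiproliferative activity, read by MTT assay, with a stated time of 24 h; a lower number here means a stronger inhibitor, a higher number a weaker inhibitor:
- Compound 1 `COc1cc(OC)c(-c2coc3cc(OCc4ccccc4C(F)(F)F)ccc3c2=O)cc1OC`: > 10000 nM, a limit.
- Compound 2 `COc1cc(OC)c(-c2coc3cc(OCc4ccccc4C#N)ccc3c2=O)cc1OC`: > 10000 nM, a limit.
- Compound 3 `COc1cc(OC)c(-c2coc3cc(OCc4ccc(Cl)cc4)ccc3c2=O)cc1OC`: 4400 nM.

Going by the values given here, compound 3 is the only compound with a number, and the rest of the series stands at the limit of > 10000 nM in this assay, at which 2 of the 3 values shown sit. Compound 4 `COc1cc(OC)c(-c2coc3cc(OCc4cccc(C(F)(F)F)c4)ccc3c2=O)cc1OC` differs from it by 3-(trifluoromethyl)phenyl in place of 4-chlorophenyl on a saturated chain carbon bound to an oxygen on an aromatic ring, with 3-(trifluoromethyl)phenyl in place of 4-chlorophenyl. Among the compounds with values here, two measured steps bear on this: an at least 2.2-fold lower number from compound 1 to compound 3 (0.35 log units; beyond the scatter) and an at least 2.2-fold lower number from compound 2 to compound 3 (0.35 log units; beyond the scatter). Both replace another substituted phenyl with 4-chlorophenyl, and the first leaves a trifluoromethyl-bearing group. Losing 4-chlorophenyl is therefore expected to reverse part of that gain in this assay. The expected change is a 1.7-fold higher number from compound 3 to compound 4 (0.23 log units; within the scatter), a modest move to a higher number. Compound 4 is estimated at 7500 nM, within an expected range of 3000 nM to 18000 nM.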

Compound 4, half-maximal inhibitory concentration: > 10000 nM
Compound 4: a limit, no number (the forecaster's own chance of this, stated with the estimate: 45%); at least 1.3-fold (0.12 log units) between middle value and limit.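

In this assay, a trifluoromethyl-bearing phenyl on this saturated chain carbon also fails to hold what 4-chlorophenyl gives, now with 3-(trifluoromethyl)phenyl entering: an at least 2.2-fold higher number from compound 3 to compound 4 (0.35 log units; beyond the scatter). The value of compound 4 is a limit, not a number. The steps among compound 1, compound 2 and compound 4 cannot be read, and compound 3 remains the only compound with a number: the limit of > 10000 nM in this assay, at which 3 of the 4 values shown sit.

Open, from the compounds shown here alone, is whether the chlorine itself or its place on the phenyl carries the difference, as this change alters both. Also open, going by these compounds, is how an amine or a carboxylic acid on this phenyl, or a longer chain to it, would read.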